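Amide cap variation on the piperidine carbonyl

The source may hold more compounds than are shown below. What is called first, only, known or untested is meant among the compounds shown, and "the series" means these compounds.

Two compounds have numbers in a functional assay on isolated protein for inhibition of Glucose-dependent insulinotropic receptor (Rattus norvegicus), read by HTRF and cAMP accumulation; on this read-out higher numbers stand for an effect only at larger amounts of compound and lower numbers for an effect already at smaller amounts. Compound 1 `Cc1nc(S(C)(=O)=O)ccc1Oc1ncnc(OC2CCN(C(=O)OC(C)(C)CF)CC2)c1F` gives 138 nM. Compound 2 `Cc1nc(S(C)(=O)=O)ccc1Oc1ncnc(OC2CCN(C(=O)C(C)(F)F)CC2)c1F` gives 239 nM. For the measured compounds named here, the only measured step, a 1.7-fold higher number from compound 1 to compound 2 (0.24 log units; within the scatter), exchanges the whole group on the carbonyl carbon, and the two values lie within the scatter of each other, so compound 2 cannot be placed above or below compound 1 on these numbers.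

Compound 3 `Cc1nc(S(C)(=O)=O)ccc1Oc1ncnc(OC2CCN(C(=O)C(C)(C)F)CC2)c1F` is not yet measured. It differs from compound 2 by methyl in place of fluoro on a saturated chain carbon bound to a carbonyl carbon, a fluorine atom and a saturated chain carbon. The step from compound 1 to compound 2 bears on this change in that it also alters the group on the carbonyl carbon, and it stayed within the scatter. Going by the values given here, no measured step isolates a fluoro-to-methyl swap on that carbon, so nothing beyond the scatter is expected in this assay. The step from compound 2 to compound 3 is estimated at a 1.2-fold lower number from compound 2 to compound 3 (0.08 log units; within the scatter). For compound 3 the expected value is 200 nM, with a range of 90 nM to 450 nM.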

Compound 3, half-maximal effective concentration: 296 nM
Compound 3: middle estimate off by 1.5-fold (0.17 log units), on the low side; the measured number falls inside the stated range.
By their numbers in this assay, from the lowest: compounds 1, 2 and 3 (each within the scatter of the next, the first and the last beyond it).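

In this assay, methyl in place of fluoro on a saturated chain carbon bound to a carbonyl carbon, a fluorine atom and a saturated chain carbon gives a 1.2-fold higher number from compound 2 to compound 3 (0.09 log units; within the scatter) and so leaves the 1,1-difluoroethyl and 1-fluoro-1-methylethyl caps indistinguishable on these numbers. The set now also holds its first step beyond the scatter, a modest 2.1-fold higher number from compound 1 to compound 3 (0.33 log units; beyond the scatter) that exchanges the whole group on the carbonyl carbon and therefore cannot be assigned to any one part of that group, while compound 2 remains within the scatter of both other compounds. Nothing available gives a reason for either step.

Compound 1 carries an oxygen on the carbonyl carbon, and compound 3 does not. For the compounds shown here, no measured step separates that oxygen from the rest of the group. Also open is whether a trifluoromethyl group, a cyclopropyl ring or a longer chain on the carbonyl carbon would stay within the scatter of these compounds or move the number further in either direction.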